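This account rests on a few compounds, and the source may have more. Where it says the series, first, only, none or still open, it means among the compounds named here.

Compound 1 `O=Cc1c(-c2ccc(F)cc2)nc2sc(Cc3ccc(Cl)cc3)nn12` and compound 2 `O=Cc1c(-c2ccccc2)nc2sc(Cc3ccc(Cl)cc3)nn12` share one core and differ only at the para position of the pendant phenyl ring. In a functional assay on L1210 cells (Mus musculus) for cytotoxicity, with a stated time of 48 h (on this read-out lower numbers stand for stronger inhibition and higher numbers for weaker inhibition), compound 1 gives 20000 nM, and compound 2 gives 20000 nM; the step of no change at the digits printed from compound 1 to compound 2 (within the scatter) is flat. Compound 3 `O=Cc1c(-c2ccc([N+](=O)[O-])cc2)nc2sc(Cc3ccc(Cl)cc3)nn12` differs from compound 2 by nitro in place of hydrogen on an aromatic carbon. For the measured compounds named here, the only step known at this position, no change at the digits printed from compound 1 to compound 2 (within the scatter), moved nothing, so compound 3 is expected to stay level, with an estimated step of no change at the digits printed from compound 2 to compound 3 (within the scatter) in this assay. The estimate for compound 3 is therefore 20000 nM, within a range from 7000 nM to 40000 nM.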

Compound 3, half-maximal inhibitory concentration: 15000 nM
For compound 3 the middle estimate is 1.3-fold (0.12 log units) above the measured one; the measured number falls inside the stated range.
By their numbers in this assay, from the lowest: compounds 3, 1 and 2 (each within the scatter of the next).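

In this assay, nitro at this position gives a 1.3-fold lower number from compound 2 to compound 3 (0.12 log units; within the scatter) and, set against fluoro, a 1.3-fold lower number from compound 1 to compound 3 (0.12 log units; within the scatter). The series thus now spans hydrogen, fluoro and a group of 3 heavy atoms with 2 hydrogen-bond acceptors, and all three stay within the scatter of one another. Nothing available explains this flat result. From the compounds shown here alone, whether an amine or a carboxylic acid at this position would also stay level remains open, as does the contribution of the other parts of the shared core.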